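The source may hold more compounds than are shown below. What is called first, only, known or untested is meant among the compounds shown, and "the series" means these compounds.

Measured in a functional assay on HEK293 cells (Homo sapiens) for cytotoxicity; on this read-out higher numbers stand for lower toxicity in this test and lower numbers for higher toxicity in this test:
Compound 1 `COc1ccc([C@H]2CC(=O)N(c3cccc(N)c3C)C2)cc1OC1CCCC1`: > 10000 nM, a limit.
Compound 2 `COc1ccc([C@H]2CC(=O)N(c3cccc(C(F)(F)F)c3)C2)cc1OC1CCCC1`: > 10000 nM, a limit.
Compound 3 `COc1ccc([C@H]2CC(=O)N(c3cccnc3)C2)cc1OC1CCCC1`: > 10000 nM, a limit.

Compound 2 has no exact number, and its > 10000 nM is a limit. The whole set stands at the limit of > 10000 nM in this assay, at which 3 of the 3 values shown sit.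

Compound 4 `COc1ccc([C@H]2CC(=O)N(c3cccc(NC(=O)C(C)=O)c3)C2)cc1OC1CCCC1` carries (acetylcarbonyl)amino in place of the trifluoromethyl of compound 2, on an aromatic carbon, meta to a large group: (acetylcarbonyl)amino in place of trifluoromethyl on an aromatic carbon.

The closest measured changes replace the whole group on the amide-type nitrogen in a ring: a step that the two limits leave unreadable from compound 1 to compound 2, a step that the two limits leave unreadable from compound 1 to compound 3 and a step that the two limits leave unreadable from compound 2 to compound 3. None of these has a readable size, so they supply no size to carry over to the new change. For the measured compounds named here, all three measured compounds remain at the limit, and no compound goes against this.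

Compound 4 is therefore expected to stay near that limit in this assay, with no step beyond the scatter. The expected outcome is a step that the limit leaves unreadable from compound 2 to compound 4. For compound 4 the estimated value is 15000 nM, with an expected range from 5000 nM to 50000 nM.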

Compound 4, half-maximal cytotoxic concentration: > 10000 nM
Compound 4 was reported as a limit; the forecaster's own chance of this, stated with the estimate: 85%; the middle value is on the limit's open side.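

In this assay compound 4 gives > 10000 nM as a limit. For the compounds shown here, compound 2 also stands only at a limit, so no step from compound 2 to compound 4 can be read. The compounds shown leave open which change to the shared core would give an exact value.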